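Indole Attachment Shift on a Trimethoxyphenyl Core

The source may report more compounds than this note shows. Statements on the series, on what has been measured and on what is new or still open speak of the compounds shown alone.

Measured compounds:
compound 1 `COc1cc(-c2ccnc3cc(-c4ccc5cc[nH]c5c4)nn23)cc(OC)c1OC` with 55 nM
compound 2 `COc1cc(-c2ccnc3cc(-c4ccc(N(C)C)cc4)nn23)cc(OC)c1OC` with 702 nM
compound 3 `COc1ccc(-c2cc3nccc(-c4cc(OC)c(OC)c(OC)c4)n3n2)cc1` with 1410 nM

The three compounds share a core and differ only in the aryl group carried on it. In a functional assay on B16-F0 cells (Mus musculus) for inhibition, read by CCK-8 assay, with a stated time of 48 h (a lower number here means a stronger inhibitor, a higher number a weaker inhibitor), compound 1 gives the lowest number of the three. The steps away from it are both large: a 13-fold higher number from compound 1 to compound 2 (1.11 log units; beyond the scatter) and a 26-fold higher number from compound 1 to compound 3 (1.41 log units; beyond the scatter). Between the two weaker compounds the gap is small, a 2.0-fold higher number from compound 2 to compound 3 (0.30 log units; within the scatter).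

Compound 4 `COc1cc(-c2ccnc3cc(-c4cn(C)c5ccccc45)nn23)cc(OC)c1OC` is not yet measured. It differs from compound 1 in one place: 1-methyl-1H-indol-3-yl in place of 1H-indol-6-yl on an aromatic carbon. Both measured steps from compound 1 bear on this change only loosely, since in each of them the indole was exchanged for a phenyl ring carrying a single substituent, whereas compound 4 keeps an indole but changes the attachment point and replaces the hydrogen-bond donor with a methyl on the ring nitrogen. The large losses in a 13-fold higher number from compound 1 to compound 2 (1.11 log units; beyond the scatter) and a 26-fold higher number from compound 1 to compound 3 (1.41 log units; beyond the scatter) show that the group in this place matters strongly, so some weakening is expected, though less than from a full loss of the indole. The expected step is a 4.5-fold higher number from compound 1 to compound 4 (0.66 log units; beyond the scatter). Compound 4 is estimated at 250 nM, within a range from 70 nM to 900 nM.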

Compound 4, half-maximal inhibitory concentration: 185 nM
Compound 4: the middle estimate sits 1.4-fold (0.13 log units) above what was measured; the measured number falls inside the stated range.
By their numbers in this assay, from the lowest: compound 1; then compound 4; then compounds 2 and 3 (each within the scatter of the next).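

In this assay, the step of a 3.4-fold higher number from compound 1 to compound 4 (0.53 log units; beyond the scatter) is smaller than either step from compound 1 to a phenyl compound, so an indole joined through a different ring carbon, with a methyl in place of the hydrogen on its ring nitrogen, retains more of the low number of compound 1 than either substituted phenyl group does. The comparisons with the phenyl compounds, a 7.6-fold lower number from compound 3 to compound 4 (0.88 log units; beyond the scatter) and a 3.8-fold lower number from compound 2 to compound 4 (0.58 log units; beyond the scatter), place compound 4 clearly on the lower side of both, which shows that a low number at this position does not depend on the hydrogen-bond donor of 1H-indol-6-yl, although compound 1, which has that donor, still gives the lowest number. No evidence is available that accounts for these differences.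

The compounds shown leave the shift in attachment point and the methyl on the ring nitrogen unseparated, as the two change together in the single step from compound 1 to compound 4. Also open, going by these compounds, is how an indole carrying a primary amine or a carboxylic acid would read in this assay.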